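A few compounds are considered here, and "the series" means these few. Any claim that something is new, unique, unknown or untested is made for them only; others in the source may bear on it.

In a physicochemical assay for lipophilicity, measured as octanol-water partition (on this read-out lower numbers stand for lower lipophilicity and higher numbers for higher lipophilicity), three compounds sharing one core have been measured: compound 1 `O=C(NNc1ccnc2cc(Cl)ccc12)c1ccccc1/N=C/c1ccc(F)cc1` gives 5.18, compound 2 `O=C(NNc1ccnc2cc(Cl)ccc12)c1ccccc1/N=C/c1cccc(Cl)c1Cl` gives 6.1, and compound 3 `O=C(NNc1ccnc2cc(Cl)ccc12)c1ccccc1/N=C/c1ccc(Br)cc1` gives 5.76, the middle of the three. Compound 4 `COc1ccc(/C=N/c2ccccc2C(=O)NNc2ccnc3cc(Cl)ccc23)cc1` differs from compound 3 in one place, with methoxy in place of bromo on an aromatic carbon. The closest guide is the exchange of fluoro for bromo at that same place, which gave a number 0.58 log units higher from compound 1 to compound 3 (beyond the scatter). The change of the whole ring group gave a number 0.34 log units lower from compound 2 to compound 3 (beyond the scatter). Among the measured compounds shown here, no methoxy compound has been measured, so any expectation is uncertain, but a modest fall, of about the size of the fluoro-to-bromo step, seems likely. The expected step is a number 0.66 log units lower from compound 3 to compound 4 (beyond the scatter). Compound 4 is estimated at 5.1, within a range of 4.7 to 5.5.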

Compound 4, partition coefficient: 5
Estimate against measurement, compound 4: 0.10 log units above, within the range that was stated.
By their numbers in this assay, from the lowest: compounds 4 and 1 (each within the scatter of the next); then compound 3; then compound 2.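

In this assay, methoxy in place of bromo on this aromatic carbon gives a number 0.76 log units lower from compound 3 to compound 4 (beyond the scatter) and so shows that this position also responds to a group that is not a halogen. Methoxy in place of fluoro gives a number 0.18 log units lower from compound 1 to compound 4 (within the scatter), so these two groups cannot be told apart here. The 4-methoxyphenyl group in place of 2,3-dichlorophenyl gives a number 1.10 log units lower from compound 2 to compound 4 (beyond the scatter), the largest step in this set.

Nothing shown explains these steps. Where an amine or a carboxylic acid at this same place would fall in this assay remains open.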